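Swapping the Sulfonate Aryl Group: Compound 4 Awaits Measurement

The source may hold more compounds than are shown below. What is called first, only, known or untested is meant among the compounds shown, and "the series" means these compounds.

Compound 1 `O=c1cc(CSc2nc3ccccc3c(=O)[nH]2)c2ccc(OS(=O)(=O)c3ccccc3[N+](=O)[O-])cc2o1`: 144000 nM
Compound 2 `Cc1ccc(S(=O)(=O)Oc2ccc3c(CSc4nc5ccc(C)cc5c(=O)[nH]4)cc(=O)oc3c2)cc1`: 114000 nM
Compound 3 `Cc1ccc(S(=O)(=O)Oc2ccc3c(CSC4=NCCC(=O)N4)cc(=O)oc3c2)cc1`: 60200 nM

Of the compounds shown here, three sharing a coumarin-like core have been tested in an ADME assay on Vero cells (Chlorocebus sabaeus) for cytotoxicity, read by polymerase chain reaction, with a stated time of 18 h; a higher number here means that more compound is tolerated, a lower number that less compound is tolerated. Compound 1 gives 144000 nM, compound 2 gives 114000 nM and compound 3 gives 60200 nM. Compound 3 therefore sits at the low end of the three numbers: its gap to compound 2 is within the scatter, while its gap to compound 1 is beyond it. Within the data shown here, the only single-point step among the measured compounds is a 1.9-fold lower number from compound 2 to compound 3 (0.28 log units; within the scatter), which concerns the group on the thioether sulfur, not the sulfonate.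

Compound 4 `O=C1CCN=C(SCc2cc(=O)oc3cc(OS(=O)(=O)c4ccccc4[N+](=O)[O-])ccc23)N1` is built from compound 3 by the change (2-nitrophenyl in place of 4-methylphenyl on a sulfonyl sulfur). Among the measured compounds shown here, no measured step touches this position directly. Compounds 1 and 2, which carry the two aryl sulfonates in question but also differ elsewhere, give values that lie within the scatter of each other, so there is no indication that this exchange moves the number by much. The expectation for compound 4 in this assay is a step of a 1.2-fold higher number from compound 3 to compound 4 (0.07 log units; within the scatter), that is, none beyond the scatter. Compound 4 is estimated at 70000 nM, with a range from 30000 nM to 160000 nM.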

Compound 4, half-maximal cytotoxic concentration: 75200 nM
Beside the measured number, compound 4's estimate is 1.1-fold (0.03 log units) below it, within the range that was stated.
By their numbers in this assay, from the lowest: compounds 3, 4, 2 and 1 (each within the scatter of the next, the first and the last beyond it).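

In this assay, among these compounds, a 1.2-fold higher number from compound 3 to compound 4 (0.10 log units; within the scatter) gives the first direct reading of 2-nitrophenyl in place of 4-methylphenyl on a sulfonyl sulfur, with the rest of the molecule held the same, and this exchange stays within the scatter, so the assay does not tell these two aryl groups apart on this scaffold. The second new step, a 1.9-fold lower number from compound 1 to compound 4 (0.28 log units; within the scatter), concerns the group on the thioether sulfur with 2-nitrophenyl held in place; it is also within the scatter and has the same printed size as a 1.9-fold lower number from compound 2 to compound 3 (0.28 log units; within the scatter), the corresponding change with 4-methylphenyl on the sulfonyl sulfur, although that pair also carries a methyl group on the larger group that leaves. No measurement shown here offers an explanation for these readings.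

Among the compounds shown here, only two aryl groups have been read on the sulfonyl sulfur, so it remains open whether a plain methyl, a longer alkyl chain, or a phenyl ring bearing an amine or a carboxylic acid would give a step beyond the scatter. With a single assay shown, these compounds also leave open whether the exchange matters for any other measurement.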